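The source may hold more compounds than are shown below. What is called first, only, known or untested is meant among the compounds shown, and "the series" means these compounds.

Values in a functional assay on OVCAR-8 cells (Homo sapiens) for inhibition, read by sulforhodamine B assay, with a stated time of 48 h, tested at 10 uM; on this read-out lower numbers stand for a stronger effect and higher numbers for a weaker effect at the one concentration tested:
compound 1, `O=C(Nc1cccc(-n2cc(-c3ccncc3)c(-c3cc(O)cc(Cl)c3)n2)c1)Nc1ccc(Cl)c(C(F)(F)F)c1`: 3.69%
compound 2, `COc1cc(Cl)cc(-c2nn(-c3cccc(NC(=O)Nc4ccc(Cl)c(C(F)(F)F)c4)c3)cc2-c2ccncc2)c1`: 8.71%
compound 3, `O=C(Nc1cccc(-n2cc(-c3ccncc3)c(-c3cc(O)cc(Cl)c3)n2)c1)c1cc(C(F)(F)F)cc(C(F)(F)F)c1`: 39.6%

Compound 3 stands highest of the three in this assay, beyond the scatter from compound 2 and from compound 1. The difference between the core of compound 1 and the core of compound 3 is not broken down here.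

Compound 1 and compound 2 differ by methyl in place of hydrogen on an oxygen on an aromatic ring; this gave a number 5 percentage points higher from compound 1 to compound 2 (within the scatter).

Compound 4, `COc1cc(Cl)cc(-c2nn(-c3cccc(NC(=O)c4cc(C(F)(F)F)cc(C(F)(F)F)c4)c3)cc2-c2ccncc2)c1`, is not yet measured. It differs from compound 3 by methyl in place of hydrogen on an oxygen on an aromatic ring, the same change as from compound 1 to compound 2, at a place described in identical words. For compound 4 a step of a number 3.4 percentage points higher from compound 3 to compound 4 (within the scatter) is expected in this assay, beside the earlier step, because a number 5 percentage points higher from compound 1 to compound 2 (within the scatter) lay within the scatter. Compound 4 is estimated at 43%, from 26% to 60%.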

Compound 4, a percentage reported as activity, at one concentration (the size of the read-out at that concentration, not a potency): 55.4%
For compound 4 the middle estimate is 12.4 percentage points below the measured one, within the range that was stated.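

In this assay, hydroxy to methoxy on the core of compound 3 gives a number 15.8 percentage points higher from compound 3 to compound 4 (beyond the scatter). Set beside the earlier step, the two results do not separate the cores: the same change on two cores in this assay, a number 5 percentage points higher (within the scatter) from compound 1 to compound 2 and a number 15.8 percentage points higher (beyond the scatter) from compound 3 to compound 4, 10.8 percentage points apart, within the scatter of two such steps. This shows that the change can be carried from one core to the other without a difference that can be told from scatter, but with one pair per core it does not show that the step has a fixed size, or that it would hold on any further core.

As far as these compounds go, it remains open whether a longer chain on that oxygen, or an amine in place of the hydroxy, would behave alike on both cores.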